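Swapping Methoxy for Chloro: Expected Antiproliferative Potency

This account rests on a few compounds, and the source may have more. Where it says the series, first, only, none or still open, it means among the compounds named here.

Measured compounds:
Compound 1 `COc1ccc(N2C(=O)COc3ccc(-c4cnc(OC)c(NS(=O)(=O)c5ccc(F)cc5)c4)cc32)cc1` gives 13100 nM in a functional assay on HepG2 cells (Homo sapiens) for antiproliferative activity, read by MTT assay, with a stated time of 72 h; a lower number here means a stronger inhibitor, a higher number a weaker inhibitor.
Compound 2 `COc1ncc(-c2ccc3c(c2)N(c2ccc(Cl)cc2)C(=O)CO3)cc1NS(=O)(=O)c1ccc(F)cc1` gives 17900 nM.
Compound 3 `COc1ncc(-c2ccc3c(c2)N(C2CC2)C(=O)CO3)cc1NS(=O)(=O)c1ccc(F)cc1` gives 14400 nM.

Compound 1 has the lowest of the three numbers, but its steps to the others, a 1.4-fold higher number from compound 1 to compound 2 (0.14 log units; within the scatter) and a 1.1-fold higher number from compound 1 to compound 3 (0.04 log units; within the scatter), both lie within the scatter, so none of the three can be called the stronger inhibitor. Compound 4 `COc1ccc(N2C(=O)COc3ccc(-c4cnc(Cl)c(NS(=O)(=O)c5ccc(F)cc5)c4)cc32)cc1` differs from compound 1 by a single exchange: chloro in place of methoxy on an aromatic carbon. Within the data shown here, the only measured step with the same kind of exchange, made in a different part of the molecule, is a 1.4-fold higher number from compound 1 to compound 2 (0.14 log units; within the scatter), which stayed within the scatter. I therefore expect no step beyond the scatter in this assay, a 1.1-fold higher number from compound 1 to compound 4 (0.03 log units; within the scatter). Compound 4 is estimated at 14000 nM, with a range from 6000 nM to 32000 nM.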

Compound 4, half-maximal inhibitory concentration: > 40000 nM
Compound 4 was reported as a limit; the forecaster's own chance of this, stated with the estimate: 5%; middle value at least 2.8-fold (0.45 log units) away from the limit.
By their numbers in this assay, from the lowest: compounds 1, 3 and 2 (each within the scatter of the next). At a limit, above all of these: compound 4.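

In this assay, among these compounds, chloro in place of methoxy next to the ring nitrogen gives an at least 3.0-fold higher number from compound 1 to compound 4 (0.48 log units; beyond the scatter), the only step here beyond the scatter. The same kind of exchange elsewhere in the molecule, a 1.4-fold higher number from compound 1 to compound 2 (0.14 log units; within the scatter), did not show this, so the outcome of the exchange depends on where it is made in these two cases. The value of compound 4 is a limit, not a number: the limit of > 40000 nM in this assay, at which 1 of the 4 values shown sits.

Going by these compounds, how far compound 4 lies past that limit remains unknown. On these data alone, whether an amine or an ethoxy group at this position would stay close to compound 1 also remains open.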